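This account rests on a few compounds, and the source may have more. Where it says the series, first, only, none or still open, it means among the compounds named here.

The measured compounds are compound 1 `CC(C)NC(=O)c1ccc(-c2onc3ccc(C(=O)O)cc23)cc1`, compound 2 `Cc1cccc(-c2onc3ccc(C(=O)O)cc23)c1` and compound 3 `O=C(O)c1ccc2noc(-c3cccc(NC(=O)C4CC4)c3)c2c1`. In an assay for inhibition of inositol hexakisphosphate kinase 2 (Homo sapiens), read by colorimetric assay, coupled enzyme assay and malachite green, with a stated time of 120 min, in the presence of a further agent that is not named here (on this read-out higher numbers stand for weaker inhibition and lower numbers for stronger inhibition), compound 1 gives 350 nM, compound 2 gives 150 nM and compound 3 gives 410 nM.

Compound 3 carries the highest of the three numbers. Among the measured compounds shown here, compound 1 sits within the scatter of it, so the two cannot be ordered; compound 2 is set apart from it by a 2.7-fold higher number from compound 2 to compound 3 (0.44 log units; beyond the scatter), the only one-place change among the measured compounds.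

Compound 4 `O=C(O)c1ccc2noc(-c3cccc(Oc4ccccn4)c3)c2c1` differs from compound 3 by (pyridin-2-yl)oxy in place of (cyclopropylcarbonyl)amino on an aromatic carbon. For the measured compounds named here, the single measured step that bears on this site is a 2.7-fold higher number from compound 2 to compound 3 (0.44 log units; beyond the scatter), a modest weakening when the leaving group first appeared in place of methyl. Going by the values given here, no measured pair shows the entering group, so its effect is unknown; the one relevant step suggests a substituent of some size at this position is tolerated with at most a modest change. A step near the scatter, in either direction, is therefore expected in this assay.

Compound 4 is expected to give 450 nM, within 150 nM to 1400 nM. This estimate amounts to a 1.1-fold higher number from compound 3 to compound 4 (0.04 log units; within the scatter), an expectation rather than a measurement.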

Compound 4, half-maximal inhibitory concentration: 690 nM
The estimate for compound 4 lay 1.5-fold (0.19 log units) below the measured number; low and high end bracket the measured number.
By their numbers in this assay, from the lowest: compound 2; then compounds 1, 3 and 4 (each within the scatter of the next).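

In this assay, replacing (cyclopropylcarbonyl)amino with (pyridin-2-yl)oxy gives a 1.7-fold higher number from compound 3 to compound 4 (0.23 log units; within the scatter) and so cannot be told apart from the scatter, which shows that this position takes a group with a six-membered aromatic ring and 0 hydrogen-bond donors without a step that can be read. Measured against methyl, the same group gives a 4.6-fold higher number from compound 2 to compound 4 (0.66 log units; beyond the scatter) and joins (cyclopropylcarbonyl)amino in lying beyond the scatter from compound 2, so among compounds 2, 3 and 4 methyl keeps the lowest number at this position. Nothing measured here offers an explanation for these steps.

The compounds shown leave open how phenoxy would compare with (pyridin-2-yl)oxy, and so whether the ring nitrogen matters. They also leave open how a small group such as methoxy, an amine or a carboxylic acid would behave at this place.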